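The source may hold more compounds than are shown below. What is called first, only, known or untested is meant among the compounds shown, and "the series" means these compounds.

In an ADME assay on microsomes from liver (Homo sapiens) for metabolic stability, read by LC-MS, using NADPH, with a stated time of 60 min, tested at 0.1 uM (on this read-out higher numbers stand for a more stable compound and lower numbers for a less stable compound), compound 3 (`Fc1ccc(Nc2cc3[nH]c(Nc4ccc(N5CCNCC5)cn4)nc3cn2)cc1F`) gives 92% and stands level with compound 1 (`Fc1ccc(Nc2cc3[nH]c(Nc4ccc(N5CCNCC5)cn4)nc3cn2)cc1C(F)(F)F`), whose figure is 92% as well. Compound 2 (`C[C@@H]1CN(c2ccc(Nc3nc4cnc(Nc5ccc(F)c(C(F)(F)F)c5)cc4[nH]3)nc2)C[C@H](C)O1`) sits far lower at 17% on this scale.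

Compound 4 (`C[C@@H]1CN(c2ccc(Nc3nc4cnc(Nc5ccc(F)c(F)c5)cc4[nH]3)nc2)C[C@H](C)N1`) differs from compound 3 in one group: 3,5-dimethylpiperazin-1-yl in place of piperazin-1-yl on an aromatic carbon.

Among the compounds with values here, two measured steps bear on this change. Fluoro in place of trifluoromethyl gave no change at the digits printed from compound 1 to compound 3 (within the scatter) and does not touch the group that changes now. 2,6-Dimethylmorpholin-4-yl in place of piperazin-1-yl gave a number 75 percentage points lower from compound 1 to compound 2 (beyond the scatter) and is the closer guide, as it alters the same group and likewise brings in two methyl groups. That step also swaps a ring atom, which compound 4 does not, and the data cannot show how much of the large drop belongs to the methyl groups alone. A drop smaller than that one is therefore expected (a number 22 percentage points lower from compound 3 to compound 4 (beyond the scatter)). For compound 4 the estimated value is 70% within an expected range (40% to 92%).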

Compound 4, percent of the compound remaining: 63%
Estimate against measurement, compound 4: 7 percentage points above, within the range that was stated.
By their numbers in this assay, from the lowest: compound 2; then compound 4; then compounds 1 and 3 (each within the scatter of the next).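

Adding two methyl groups to the piperazine ring while leaving its ring atoms unchanged gives a number 29 percentage points lower from compound 3 to compound 4 (beyond the scatter) in this assay on this scale. The earlier change at this position, to 2,6-dimethylmorpholin-4-yl, brought in methyl groups and swapped a ring atom at the same time, whereas this step shows that the methyl groups alone, on an otherwise unchanged ring, are enough to move the read-out beyond the scatter. Nothing available here explains why this substitution lowers the percentage remaining.

The compounds shown leave open how morpholin-4-yl, with its ring oxygen but no methyl groups, would score, which would give the ring atom a step of its own. Going by these compounds, it also remains open whether one methyl group, as in 3-methylpiperazin-1-yl, would have a similar effect.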